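Notes on a dinucleoside conjugate series, HeLa cytotoxicity

This account rests on a few compounds, and the source may have more. Where it says the series, first, only, none or still open, it means among the compounds named here.

The series is read in an ADME assay on HeLa cells (Homo sapiens) for cytotoxicity, read by MTT assay, with a stated time of 48 h; on this read-out lower numbers stand for an effect already at smaller amounts and higher numbers for an effect only at larger amounts of compound. Compound 1 `CC(=O)N[C@@H](CCC(=O)OC[C@H]1O[C@@H](n2cc(C)c(=O)[nH]c2=O)C[C@@H]1N=[N+]=[N-])C(=O)OC[C@@H]1O[C@H](n2ccc(N)nc2=O)CS1` gives in this assay only a limit, > 154000 nM. Compound 2 `Cc1cn([C@H]2C[C@H](N=[N+]=[N-])[C@@H](COC(=O)CC[C@H](NC(=O)CCC(=O)OC[C@H]3O[C@@H](n4cc(C)c(=O)[nH]c4=O)C[C@@H]3F)C(=O)OC[C@@H]3O[C@H](n4ccc(N)nc4=O)CS3)O2)c(=O)[nH]c1=O` likewise gives only a limit, > 107000 nM. Among the measured compounds shown here, both values shown are thus limits, one sitting at the limit of > 107000 nM in this assay, at which 1 of the 2 values shown sits, and one at the limit of > 154000 nM in this assay, at which 1 of the 2 values shown sits; no measured step between two numbers exists, so compound 1 can be placed only as sitting at its own limit. Compound 3 `CCCCCCCCCCCCCC(=O)N[C@@H](CCC(=O)OC[C@H]1O[C@@H](n2cc(C)c(=O)[nH]c2=O)C[C@@H]1N=[N+]=[N-])C(=O)OC[C@@H]1O[C@H](n2ccc(N)nc2=O)CS1` is to be measured in this assay. It differs from compound 1 by dodecyl in place of hydrogen on a saturated chain carbon bound to a carbonyl carbon. With nothing measured beyond limits, no step beyond the usual scatter is expected, and the step from compound 1 to compound 3 is estimated at an at least 1.0-fold lower number from compound 1 to compound 3 (0.01 log units; that floor lies within the scatter). Compound 3 is expected to give 150000 nM, with a range from 50000 nM to 400000 nM, most likely again reported as a limit.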

Compound 3, half-maximal effective concentration: > 122000 nM
Compound 3: no number, only a limit (the forecaster's own chance of this, stated with the estimate: 70%); the middle value does not contradict the limit.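

Compound 1 and compound 3 are both recorded only as limits, so no step can be read between them. The compounds shown leave open at what concentration any of them reaches a half-maximal effect in this assay, and whether dodecyl in place of hydrogen shifts that concentration.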